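Shortening the chain from compound 3 to compound 4

The source may report more compounds than this note shows. Statements on the series, on what has been measured and on what is new or still open speak of the compounds shown alone.

Measured compounds:
- compound 1, `CCCCCCCCCCCCCCCCCCNC(=O)NCc1c(OC)cc(OC)cc1OC`: > 5000 nM in an assay on microsomes from intestinal mucosa for inhibition of acyl-CoA:cholesterol acyltransferase (Oryctolagus cuniculus); on this read-out higher numbers stand for weaker inhibition and lower numbers for stronger inhibition
- compound 2, `CCCCCCCCCCNC(=O)Nc1c(C(C)C)cccc1C(C)C`: 56 nM
- compound 3, `CCCCCCNC(=O)Nc1c(C(C)C)cccc1C(C)C`: 99 nM

The value of compound 1 is a limit of the assay, not a number. Among the two numbers, compound 3 stands highest, with compound 2 nearest; the step of a 1.8-fold higher number from compound 2 to compound 3 (0.25 log units; within the scatter) shows the gap, which is within the scatter. Within the data shown here, compound 1 sits at the limit of > 5000 nM in this assay, at which 1 of the 3 values shown sits, and shares no single-point step with the other two, so its value only shows that its chain and core together give no measurable inhibition.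

Compound 4, `CNC(=O)Nc1c(C(C)C)cccc1C(C)C`, differs from compound 3 by hydrogen in place of pentyl on a saturated chain carbon bound to an amide-type nitrogen; cut one bond further out, the change reads hexyl to methyl. Among the measured compounds shown here, the only measured step that bears on it is the chain shortening a 1.8-fold higher number from compound 2 to compound 3 (0.25 log units; within the scatter), which stayed within the scatter. Shortening further to methyl goes beyond that step, so the expected outcome is a small rise in the number, perhaps beyond the scatter, with a 2.5-fold higher number from compound 3 to compound 4 (0.40 log units; beyond the scatter). Compound 4 is therefore estimated at 250 nM, between 70 nM and 1500 nM.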

Compound 4, half-maximal inhibitory concentration: > 5000 nM
Compound 4: only a limit was reported; the forecaster's own chance of this, stated with the estimate: 10%; middle value at least 20-fold (1.30 log units) away from the limit.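

Shortening the chain on the amide-type nitrogen has very different outcomes depending on how far it goes: hexyl to methyl gives an at least 50-fold higher number from compound 3 to compound 4 (1.70 log units; beyond the scatter), whereas the earlier shortening gave only a 1.8-fold higher number from compound 2 to compound 3 (0.25 log units; within the scatter). On this shared core, then, a hexyl chain keeps inhibition measurable in this assay, while a methyl group does not. The value of compound 4 is a limit of the assay, not a number: the limit of > 5000 nM in this assay, at which 2 of the 4 values shown sit.

An ethyl, propyl or butyl chain in the same place would show where between hexyl and methyl the number climbs, and whether it does so gradually or abruptly. Also open, from the compounds shown here alone, is how a chain longer than that of compound 2, or a hexyl chain ending in an amine or a carboxylic acid, would read out on this core.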